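This account rests on a few compounds, and the source may have more. Where it says the series, first, only, none or still open, it means among the compounds named here.

Compound 2 `O=C(NC(=S)Nc1ccc(F)cc1)c1cn(-c2ccccc2)nc1-c1ccc(F)cc1` was tested in a functional assay on A549 cells (Homo sapiens) for inhibition, read by CCK-8 assay, with a stated time of 48 h (a higher number here means a weaker inhibitor, a lower number a stronger inhibitor), where compound 2 gives 3540 nM. Its nearest companion is compound 1 `Cc1ccc(NC(=S)NC(=O)c2cn(-c3ccccc3)nc2-c2ccc(Cl)cc2)cc1`, which in this assay gives 2690 nM, a number that sits within the usual scatter of that of compound 2. Compound 3 `O=C(NC(=S)Nc1ccc(F)cc1)c1cn(-c2ccccc2)nc1-c1ccc(Cl)cc1` has not yet been measured. It differs from compound 2 by chloro in place of fluoro on an aromatic carbon. Among the compounds with values here, no measured step of this kind exists here, so the estimated step of a 1.2-fold lower number from compound 2 to compound 3 (0.09 log units; within the scatter) is expected to be small, in neither direction beyond the scatter. Compound 3 is accordingly expected to give about 2900 nM, in the range 1400 nM to 6000 nM.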

Compound 3, half-maximal inhibitory concentration: 3980 nM
For compound 3 the middle estimate is 1.4-fold (0.14 log units) below the measured one; measured number inside the range.
By their numbers in this assay, from the lowest: compounds 1, 2 and 3 (each within the scatter of the next).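

In this assay, within the data shown here, the change from 4-fluorophenyl to 4-chlorophenyl, now measured for the first time, stays within the scatter (a 1.1-fold higher number from compound 2 to compound 3 (0.05 log units; within the scatter)), so the two halogens are not told apart at this position. Fluoro in place of methyl on an aromatic carbon likewise stays within the scatter (a 1.5-fold higher number from compound 1 to compound 3 (0.17 log units; within the scatter)). Nothing available explains either step. Going by these compounds, what remains open is whether a larger or different group at this position, such as methoxy, trifluoromethyl or an amine, would shift the number beyond the scatter.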